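Series notes: 4-bromophenyl to 4-nitrophenyl

The source may report more compounds than this note shows. Statements on the series, on what has been measured and on what is new or still open speak of the compounds shown alone.

Compound 2 `O=c1ccoc2cc(OCc3cn(Cc4ccc(Br)cc4)nn3)ccc12` carries a 4-bromophenyl group on the saturated chain carbon bound to an aromatic nitrogen. In a functional assay on HeLa cells (Homo sapiens) for cytotoxicity, read by MTT assay, with a stated time of 48 h (a lower number here means a stronger inhibitor, a higher number a weaker inhibitor), compound 2 gives only a limit, > 100000 nM. Compound 1 `O=c1ccoc2cc(OCc3cn(Cc4cccc(Br)c4)nn3)ccc12` differs in having 3-bromophenyl in that place. In this assay compound 1 likewise gives only a limit, > 100000 nM. The step that the two limits leave unreadable from compound 1 to compound 2 therefore cannot be read. Compound 2 thus stands at the limit of > 100000 nM in this assay, at which 2 of the 2 values shown sit, with no number to rank it.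

Compound 3 `O=c1ccoc2cc(OCc3cn(Cc4ccc([N+](=O)[O-])cc4)nn3)ccc12` is the next member: nitro in place of bromo on an aromatic carbon. For the measured compounds named here, no measured step in this set bears on a nitro for bromo exchange; the single measured step, from compound 1 to compound 2, gives neither direction nor size. With both measured compounds at the limit, the expectation for this assay is no readable step beyond the scatter and most likely a further limit. The step from compound 2 to compound 3 is expected to be a step that the limit leaves unreadable from compound 2 to compound 3. For compound 3 the estimate is 150000 nM, with a range from 40000 nM to 600000 nM.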

Compound 3, half-maximal inhibitory concentration: 25700 nM
The estimate for compound 3 lay 5.8-fold (0.77 log units) above the measured number, outside the stated range (below it).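

In this assay, for the compounds shown here, the aromatic carbon para to a large group turns out to be a place where a single exchange can move the read-out: nitro in place of bromo gives an at least 3.8-fold lower number from compound 2 to compound 3 (0.59 log units; beyond the scatter), the first step that can be read. The comparison with the other bromo compound points the same way, with 4-nitrophenyl in place of 3-bromophenyl giving an at least 3.8-fold lower number from compound 1 to compound 3 (0.59 log units; beyond the scatter), so the lower number holds against both places the bromine occupies in the compounds shown. Going by these compounds alone, both steps give only a minimum size, since each starts from a limit, and compound 3 is the only compound here with a number; the others remain at that limit: the limit of > 100000 nM in this assay, at which 2 of the 3 values shown sit.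

Going by these compounds, whether nitro is particular in this place, or whether an amine, a carboxylic acid or a nitrile on the same aromatic carbon would also give a number, stays open, as does how 3-nitrophenyl would compare with 4-nitrophenyl. The step between the two bromo compounds cannot be read, so nothing shown tells how the place of the substituent on this ring bears on the read-out.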